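Amide aryl exchange in the series: solubility working notes

The source may hold more compounds than are shown below. What is called first, only, known or untested is meant among the compounds shown, and "the series" means these compounds.

Measured so far:
compound 1 `COc1ccc2nc(C)cc(OCC(=O)Nc3ccccc3)c2c1` — in a physicochemical assay for solubility, in phosphate buffer, measured as kinetic solubility, with a stated time of 1 h, at pH 7.4 (on this read-out lower numbers stand for lower solubility and higher numbers for higher solubility), compound 1 gives 63000 nM
compound 2 `COc1ccc2nc(C)cc(OCC(=O)Nc3c(C)cccc3C)c2c1` — in this assay compound 2 gives 112000 nM

Among the compounds with values here, compound 2 and compound 1 sit within the scatter of each other; the single measured step, a 1.8-fold higher number from compound 1 to compound 2 (0.25 log units; within the scatter), is the only guide on this assay. Compound 3 `COc1ccc2nc(C)cc(OCC(=O)Nc3cc(F)cc(F)c3)c2c1` is not yet measured. It differs from compound 2 by 3,5-difluorophenyl in place of 2,6-dimethylphenyl on an amide-type nitrogen. That measured step is the only one that bears on this change, and it stayed within the scatter, so no step beyond the scatter is expected in this assay. For compound 3 the expected value is 80000 nM, with a range of 35000 nM to 180000 nM. This estimate means a 1.4-fold lower number from compound 2 to compound 3 (0.15 log units; within the scatter).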

Compound 3, solubility: 13000 nM
Beside the measured number, compound 3's estimate is 6.2-fold (0.79 log units) above it; measured number outside the range, below it.
By their numbers in this assay, from the lowest: compound 3; then compounds 1 and 2 (each within the scatter of the next).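

In this assay the aryl group on the amide-type nitrogen can move the read-out beyond the scatter: 3,5-difluorophenyl gives an 8.6-fold lower number from compound 2 to compound 3 (0.94 log units; beyond the scatter) and a 4.8-fold lower number from compound 1 to compound 3 (0.69 log units; beyond the scatter) here. The step between phenyl and 2,6-dimethylphenyl gave no sign of this, and compounds 2 and 3 differ here although both groups hold the same heavy-atom count. No measured evidence on hand accounts for the drop. Open, going by these compounds, is whether the fluorine atoms or their placement on the ring carry the step, and what an amine or a carboxylic acid on this aryl group would give.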